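A ring swap on the shortest-lived compound

The source may hold more compounds than are shown below. What is called first, only, known or untested is meant among the compounds shown, and "the series" means these compounds.

So far, three compounds sharing one core have been measured in an ADME assay (liver) for metabolic stability, with Liver microsome (Homo sapiens) as the target, using microsomes (a lower number here means that the compound disappears faster, a higher number that the compound lasts longer), and differ in a single group. Compound 1 `CCc1nc2cc(Cl)ccn2c1C(=O)NCc1ccc(-c2ccc(C)cc2)cc1` gives 0.423 h and compound 2 `CCc1nc2cc(Cl)ccn2c1C(=O)NCc1ccc(-c2ccncc2)cc1` gives 0.482 h here, within the scatter of each other. Compound 3 `CCc1nc2cc(Cl)ccn2c1C(=O)NCc1ccc(N2CCCCCC2)cc1` is the lowest of the three, at 0.0483 h in this test. Azepan-1-yl in place of 4-methylphenyl gives an 8.8-fold lower number from compound 1 to compound 3 (0.94 log units; beyond the scatter) and azepan-1-yl in place of pyridin-4-yl gives a 10-fold lower number from compound 2 to compound 3 (1.00 log units; beyond the scatter) in this series.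

Compound 4 `CCc1nc2cc(Cl)ccn2c1C(=O)NCc1ccc(N2CCC(Cl)CC2)cc1` carries 4-chloropiperidin-1-yl in place of azepan-1-yl on an aromatic carbon. Within the data shown here, no measured step exchanges one non-aromatic ring for another, so those two steps offer only loose guidance. Compound 3 at 0.0483 h also has a non-aromatic ring in this place, which points to a result nearer to it than to the other two compounds. For compound 4 a small rise is expected (a 1.9-fold higher number from compound 3 to compound 4 (0.27 log units; within the scatter)), well short of those two steps. Compound 4 is estimated at 0.09 h (expected range 0.04 h to 0.25 h).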

Compound 4, half-life: 0.183 h
The estimate for compound 4 lay 2.0-fold (0.31 log units) below the measured number, and the stated range covers the measured number.
By their numbers in this assay, from the lowest: compound 3; then compound 4; then compounds 1 and 2 (each within the scatter of the next).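

Within the non-aromatic rings at this position, the half-life is not fixed: in this assay, 4-chloropiperidin-1-yl in place of azepan-1-yl gives a 3.8-fold higher number from compound 3 to compound 4 (0.58 log units; beyond the scatter) even though both groups have the same number of heavy atoms. The gain does not reach the level of the compounds with an aromatic ring here, with a 2.6-fold lower number from compound 2 to compound 4 (0.42 log units; beyond the scatter) and a 2.3-fold lower number from compound 1 to compound 4 (0.36 log units; beyond the scatter) when 4-chloropiperidin-1-yl takes the place of those rings. No evidence is at hand on what lies behind these differences.

Going by these compounds, this change shrinks the ring from seven members to six and adds a chlorine in one step, so the share of each stays unknown. Plain piperidin-1-yl would separate the two, while morpholin-4-yl would show what an oxygen in the ring does at this position.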